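Chain extension at the ester end: compound 3 to compound 4

This account rests on a few compounds, and the source may have more. Where it says the series, first, only, none or still open, it means among the compounds named here.

Compound 3 `CCCCCCCCCCCCCCCOC(=O)CCC(=O)N1CCN(CCCOc2cc3c(Nc4ccc(F)c(Cl)c4)ncnc3cc2OC)CC1` gives 81.6% in a functional assay on A549 cells (Homo sapiens) for cytotoxicity, read by MTT assay, with a stated time of 24 h, tested at 60 uM (on this read-out lower numbers stand for a stronger effect and higher numbers for a weaker effect at the one concentration tested), the highest of the three numbers in hand. Its nearest neighbour is compound 1 `CCCCCCCOC(=O)CCC(=O)N1CCN(CCCOc2cc3c(Nc4ccc(F)c(Cl)c4)ncnc3cc2OC)CC1`, which gives 35.7%; furthest is compound 2 `CCCCCCCCCCCOC(=O)CCC(=O)N1CCN(CCCOc2cc3c(Nc4ccc(F)c(Cl)c4)ncnc3cc2OC)CC1`, which gives 3.9%. The numbers do not run one way along the series: a number 31.8 percentage points lower from compound 1 to compound 2 (beyond the scatter), whereas a number 45.9 percentage points higher from compound 1 to compound 3 (beyond the scatter) and a number 77.7 percentage points higher from compound 2 to compound 3 (beyond the scatter).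

Compound 4 `CCCCCCCCCCCCCCCCCCCOC(=O)CCC(=O)N1CCN(CCCOc2cc3c(Nc4ccc(F)c(Cl)c4)ncnc3cc2OC)CC1` has not been measured. Compared with compound 3 it carries butyl in place of hydrogen on a saturated chain carbon, ten or more bonds along the chain from an oxygen next to a carbonyl group. For the measured compounds named here, the step that bears most directly on this change is the one from compound 2 to compound 3, where the same butyl entry at the same kind of position went with a number 77.7 percentage points higher from compound 2 to compound 3 (beyond the scatter). The step from compound 1 to compound 2, a butyl entry closer to the carbonyl, went the other way with a number 31.8 percentage points lower from compound 1 to compound 2 (beyond the scatter), and it shows that a butyl entry in this chain is not tied to a fixed direction.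

Taking the directly matching step as the guide, compound 4 is expected to move upward or stay high, and since compound 3 already sits near the ceiling of the read-out, a modest step of a number 6.4 percentage points higher from compound 3 to compound 4 (within the scatter) is estimated. Compound 4 is thus estimated at 88%, with a range from 62% to 100%.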

Compound 4, a percentage reported as activity, at one concentration (the size of the read-out at that concentration, not a potency): 89.3%
The estimate for compound 4 lay 1.3 percentage points below the measured number; low and high end bracket the measured number.
By their numbers in this assay, from the lowest: compound 2; then compound 1; then compounds 3 and 4 (each within the scatter of the next).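

In this assay, the butyl entry on a saturated chain carbon now gives a number 7.7 percentage points higher from compound 3 to compound 4 (within the scatter), so the large upward step seen earlier at this kind of position, a number 77.7 percentage points higher from compound 2 to compound 3 (beyond the scatter), does not repeat. Over longer reaches the steps remain large, a number 85.4 percentage points higher from compound 2 to compound 4 (beyond the scatter) with an octyl entry and a number 53.6 percentage points higher from compound 1 to compound 4 (beyond the scatter) with a dodecyl entry, which places compound 4 with compound 3 at the high end of the numbers, well away from compound 2. Within these four compounds the size and direction of a butyl entry depend on the chain that receives it: the same change on two cores in this assay, a number 31.8 percentage points lower (beyond the scatter) from compound 1 to compound 2 and a number 7.7 percentage points higher (within the scatter) from compound 3 to compound 4, 39.5 percentage points apart, beyond the scatter of two such steps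

Still open, from the compounds shown here alone, is where the number turns upward between the chain of compound 2 and the chain of compound 3, and whether a longer chain than that of compound 4 stays in the same range. Also open is how a terminal amine or a carboxylic acid at the far end of the chain would read, and a single concentration gives no potency for any of these compounds.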